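Swapping the aryl group on the ring nitrogen again

The source may report more compounds than this note shows. Statements on the series, on what has been measured and on what is new or still open speak of the compounds shown alone.

Of the compounds shown here, two have been tested in a functional assay on NCI-H661 cells (Homo sapiens) for inhibition, read by MTT assay, with a stated time of 72 h; a higher number here means a weaker inhibitor of growth, a lower number a stronger inhibitor of growth. Compound 1, `CN(C)/C=N/c1c(C=O)c(-c2ccccc2)nn1-c1ccccc1Cl`, gives 31400 nM. Compound 2, `CN(C)/C=N/c1c(C=O)c(-c2ccccc2)nn1-c1cccc([N+](=O)[O-])c1`, gives 50000 nM. Among the compounds with values here, compound 2 carries the highest of the two numbers, but the only measured step, a 1.6-fold higher number from compound 1 to compound 2 (0.20 log units; within the scatter), lies within the scatter, so the two compounds cannot be told apart on these data.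

Compound 3 is `COc1ccc(-n2nc(-c3ccccc3)c(C=O)c2/N=C/N(C)C)cc1`, not yet measured. The change from compound 2 is 4-methoxyphenyl in place of 3-nitrophenyl on an aromatic nitrogen. Within the data shown here, the one measured step that bears on it is the earlier exchange of the aryl group on the same ring nitrogen, a 1.6-fold higher number from compound 1 to compound 2 (0.20 log units; within the scatter), which was small. Among the measured compounds shown here, with only that step as a guide, no change beyond the scatter is expected in this assay, though a single comparison is a thin basis. The step from compound 2 to compound 3 is therefore estimated as a 1.3-fold lower number from compound 2 to compound 3 (0.10 log units; within the scatter). Compound 3 is expected to give about 40000 nM, with a plausible range from 15000 nM to 100000 nM.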

Compound 3, concentration for 50% growth inhibition: 33400 nM
Beside the measured number, compound 3's estimate is 1.2-fold (0.08 log units) above it, within the range that was stated.
By their numbers in this assay, from the lowest: compounds 1, 3 and 2 (each within the scatter of the next).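

Within the data shown here, with a third aryl group on this ring nitrogen, this assay still shows no step that can be read as a real difference: there is a 1.5-fold lower number from compound 2 to compound 3 (0.18 log units; within the scatter) and a 1.1-fold higher number from compound 1 to compound 3 (0.03 log units; within the scatter). The earlier compounds offered a single comparison, whereas 2-chlorophenyl, 3-nitrophenyl and 4-methoxyphenyl can now be compared in pairs, and compound 1, compound 2 and compound 3 all lie within the scatter of one another, so among these three aryl groups the choice makes no measurable difference in this assay. No measurement available here explains why these three groups read alike.

From the compounds shown here alone, it remains open whether a different kind of group on this ring nitrogen, such as a longer alkyl chain or a phenyl ring carrying an amine or a carboxylic acid, would move the number beyond the scatter. Going by these compounds, it is also open whether the same result would hold with a change elsewhere on the shared core, for instance a nitrile in place of the formyl group.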